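This account rests on a few compounds, and the source may have more. Where it says the series, first, only, none or still open, it means among the compounds named here.

Compound 1 `C[C@@H](Cn1c(=O)[nH]/c(=N\c2ccc(Oc3cncc(F)c3)cc2)n(Cc2ccc(Cl)cc2)c1=O)C(=O)O` – 74.3%
Compound 2 `C[C@@H](Cn1c(=O)[nH]/c(=N\c2ccc(Oc3cnccn3)cc2)n(Cc2ccc(Cl)cc2)c1=O)C(=O)O` – 56.5%

In an ADME assay on the whole organism (Rattus norvegicus) for pharmacokinetics, using cassette dosing, at a dose of 1 mg/kg by the oral route (a lower number here means that a smaller share of the oral dose reaches the circulation, a higher number that a larger share of the oral dose reaches the circulation), compound 2 is the lower of the two measured compounds (56.5%). Compound 3 `C[C@@H](Cn1c(=O)[nH]/c(=N\c2ccc(Oc3ccccn3)cc2)n(Cc2ccc(Cl)cc2)c1=O)C(=O)O` differs from it in one place (pyridin-2-yl in place of pyrazin-2-yl on an oxygen on an aromatic ring), with pyridin-2-yl in place of pyrazin-2-yl on an oxygen on an aromatic ring. Within the data shown here, only one measured step bears on this place, a modest one (a number 17.8 percentage points lower from compound 1 to compound 2 (beyond the scatter)), and it leads from 5-fluoropyridin-3-yl to pyrazin-2-yl. Among the measured compounds shown here, no measured compound carries pyridin-2-yl itself. A small rise, perhaps within the scatter, is expected (a number 8.5 percentage points higher from compound 2 to compound 3 (within the scatter)). Compound 3 is estimated at 65% (expected range 47% to 82%).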

Compound 3, oral bioavailability: 52.8%
Compound 3: the middle estimate sits 12.2 percentage points above what was measured; the range from low to high includes it.
By their numbers in this assay, from the lowest: compounds 3 and 2 (each within the scatter of the next); then compound 1.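

In this assay, pyridin-2-yl and pyrazin-2-yl on this oxygen cannot be told apart, with a number 3.7 percentage points lower from compound 2 to compound 3 (within the scatter), so the extra ring nitrogen of pyrazin-2-yl makes no readable difference here. The gap to 5-fluoropyridin-3-yl is therefore not particular to pyrazin-2-yl, as the second group also gives a number 21.5 percentage points lower from compound 1 to compound 3 (beyond the scatter). Nothing at hand explains either step. The compounds shown leave open whether the fluorine or the point of attachment of the ring separates compound 1 from compound 3. A plain pyridin-3-yl on this oxygen would separate the two.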